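A Nitrophenyl Ester in Place of a Pyridyl Ester

The source may report more compounds than this note shows. Statements on the series, on what has been measured and on what is new or still open speak of the compounds shown alone.

Compound 1 `C=C1CC[C@H]2[C@@](C)(CCC(=O)N[C@@]2(C)COC(=O)c2ccccc2)[C@@H]1/C=C/C1=CCOC1=O`: in an assay for inhibition of hexokinase-2 (Homo sapiens), read by coupled enzyme assay, with a stated time of 10 min, in the presence of a further agent that is not named here (on this read-out lower numbers stand for stronger inhibition and higher numbers for weaker inhibition), compound 1 gives > 50000 nM, which is a limit of the assay and not a number.
Compound 2 `C=C1CC[C@H]2[C@@](C)(CCC(=O)N[C@@]2(C)COC(=O)[C@@H]2CCCN2)[C@@H]1/C=C/C1=CCOC1=O`: in this assay compound 2 gives > 50000 nM, again a limit.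
Compound 3 `C=C1CC[C@H]2[C@@](C)(CC[C@@H](OC(=O)c3cccnc3)[C@@]2(C)NC=O)[C@@H]1/C=C/C1=CCOC1=O`: in this assay compound 3 gives > 50000 nM, also a limit.

The three measured compounds share one core and differ only in the acyl group of the ester. The step from compound 1 to compound 2 is a step that the two limits leave unreadable from compound 1 to compound 2, so it cannot be read. Compound 3 stands where the other two stand: every value shown so far sits at the limit of > 50000 nM in this assay, at which 3 of the 3 values shown sit, and no number below that limit has been recorded for any of them.

Compound 4 `C=C1CC[C@H]2[C@@](C)(CC[C@@H](OC(=O)c3ccc([N+](=O)[O-])cc3)[C@@]2(C)NC=O)[C@@H]1/C=C/C1=CCOC1=O` differs from compound 3 by 4-nitrophenyl in place of pyridin-3-yl on a carbonyl carbon. Among the measured compounds shown here, no measured step bears on this change, since the only recorded step is unreadable. Because all three values rest at the limit of > 50000 nM in this assay, at which 3 of the 3 values shown sit, the expectation for compound 4 is that it stays at the limit as well. Compound 4 is therefore expected to give 80000 nM in this assay, with a range from 20000 nM to 300000 nM. The step from compound 3 to compound 4 is expected to be a step that the limit leaves unreadable from compound 3 to compound 4, not beyond the scatter.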

Compound 4, half-maximal inhibitory concentration: > 50000 nM
Compound 4: no number, only a limit; the forecaster's own chance of this, stated with the estimate: 85%; the middle value lies beyond the limit too.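

No step can be read between compound 3 and compound 4: each gives only a limit in this assay, not a number. The compounds shown leave open whether any ester of this kind would give a measurable value, and how strongly these four compounds differ, if at all: the limit of > 50000 nM in this assay, at which 4 of the 4 values shown sit.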